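The source may report more compounds than this note shows. Statements on the series, on what has been measured and on what is new or still open speak of the compounds shown alone.

Measured in a functional assay on HCT-116 cells (Homo sapiens) for antiproliferative activity, read by MTT assay, with a stated time of 48 h; a lower number here means a stronger inhibitor of growth, a higher number a weaker inhibitor of growth:
- Compound 1 `CCN(Cc1ccc(C(=O)NO)cc1)c1ncc(-c2ccc(C)cc2)s1`: 6870 nM
- Compound 2 `Cc1ccc(-c2cnc(N(CCCCOc3ccccc3)Cc3ccc(C(=O)NO)cc3)s2)cc1`: 680 nM

Of these two numbers, the lower belongs to compound 2 at 680 nM. Compound 3 `CCCCN(Cc1ccc(C(=O)NO)cc1)c1ncc(-c2ccc(C)cc2)s1` has hydrogen in place of phenoxy on a saturated chain carbon, four bonds along the chain from a nitrogen on an aromatic ring. Among the compounds with values here, only one measured step bears on this change: a 10-fold lower number from compound 1 to compound 2 (1.00 log units; beyond the scatter), with 2-phenoxyethyl in place of hydrogen. Removing phenoxy alone might undo part of that gain, but this single step is thin evidence. The expected change is a 2.9-fold higher number from compound 2 to compound 3 (0.47 log units; beyond the scatter), towards weaker growth inhibition in this assay. For compound 3 the estimated value is 2000 nM, with a range of 700 nM to 6000 nM.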

Compound 3, concentration for 50% growth inhibition: 8780 nM
The estimate for compound 3 lay 4.4-fold (0.64 log units) below the measured number; the measured number lies above the stated range.
By their numbers in this assay, from the lowest: compound 2; then compounds 1 and 3 (each within the scatter of the next).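

In this assay, the phenoxy group at this place on the chain matters more than the earlier step could show: a 13-fold higher number from compound 2 to compound 3 (1.11 log units; beyond the scatter). The plain chain alone does not account for the gain, since the ethyl added at the other listed place leaves the number within the scatter: a 1.3-fold higher number from compound 1 to compound 3 (0.11 log units; within the scatter). No measured evidence here explains the effect of phenoxy. Going by these compounds, whether its oxygen or its aromatic ring counts most stays open. Methoxy or phenyl at this place would separate the two.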